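Two Stereocentres Inverted in a Cytotoxic Compound

A few compounds are considered here, and "the series" means these few. Any claim that something is new, unique, unknown or untested is made for them only; others in the source may bear on it.

In a functional assay on HT-29 cells (Homo sapiens) for cytotoxicity, read by MTT assay, with a stated time of 7 days (a higher number here means that more compound is needed for the effect, a lower number that less compound is needed), compound 1 (`CC1=C[C@H]2[C@@H](C(C)C)CC[C@@](C)(O)[C@H]2CC1=O`) gives 7.85 ug/mL and compound 2 (`CC(C)[C@@H]1CC[C@@](C)(O)[C@]2(O)[C@@H](O)C[C@@H](C)C[C@@H]12`) gives 12 ug/mL as values within the usual scatter of each other. Compound 3 (`CC1=C[C@@H]2[C@@H](CC1=O)[C@](C)(O)CC[C@H]2C(C)C`) is not yet measured. Against compound 1 it shows the two compounds have the same atoms and bonds and differ only in configuration as drawn: 2 of 4 stereo elements differ; a stereocentre at a saturated ring carbon is drawn S in compound 1 and R in compound 3; a stereocentre at a saturated ring carbon is drawn R in compound 1 and S in compound 3 and nothing else, with the same atoms and bonds throughout. Among the measured compounds shown here, no measured pair shows a change of this kind, so in this assay no direction can be argued and no step beyond the scatter is expected. The estimate is a 1.1-fold higher number from compound 1 to compound 3 (0.06 log units; within the scatter) as the expected step. Compound 3 is expected at 9 ug/mL and between 3.5 ug/mL and 22 ug/mL on this estimate.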

Compound 3, concentration for half-maximal effect: 32.5 ug/mL
Beside the measured number, compound 3's estimate is 3.6-fold (0.56 log units) below it, outside the stated range (above it).
By their numbers in this assay, from the lowest: compounds 1 and 2 (each within the scatter of the next); then compound 3.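

In this assay, among the compounds shown here, inverting two stereocentres at saturated ring carbons comes with a 4.1-fold higher number from compound 1 to compound 3 (0.62 log units; beyond the scatter), the first step in this set that lies beyond the scatter. This step can be tied to configuration alone, because of one fact about the pair: the fact that compounds 1 and 3 differ only in the configuration as drawn

From the compounds shown here alone, both stereocentres change together in compound 3, so which of them carries the step remains open. Also open, going by these compounds, is how the core of compound 1 would read with an amine or a methyl ether in place of its hydroxyl group.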